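Replacing a Pyridyl Arm with an Ethylsulfonylamino Group

The compounds below may be only part of what the source reports. "The series", "measured", "known", "first", "only" and "open" are said of these compounds alone.

Compound 1 `c1ccc(-c2cccc3c2CCC3c2ncc[nH]2)nc1` is the point of departure. In a functional assay on CHO cells for agonist activity at Alpha-1B adrenergic receptor (Homo sapiens), read by FLIPR and calcium flux (a higher number here means that more compound is needed for the effect, a lower number that less compound is needed), compound 1 gives > 10000 nM, a limit of the assay rather than a number. Compound 1 therefore sits at the weak end of what has been seen, at the limit of > 10000 nM in this assay, at which 2 of the 3 values shown sit. Compound 2 `c1ccc2c(c1)CCCC2c1ncc[nH]1` differs from compound 1 in more than one place, and in this assay compound 2 gives 791 nM. Compound 3 `Cc1ccc2c(c1NS(C)(=O)=O)CCC2c1ncc[nH]1` in this assay gives > 10000 nM, again a limit. Compound 4 `CCS(=O)(=O)Nc1cccc2c1CCC2c1ncc[nH]1` has not yet been measured. It differs from compound 1 by (ethylsulfonyl)amino in place of pyridin-2-yl on an aromatic carbon. Within the data shown here, no measured pair differs in one place only, so this step has no direct precedent. Compound 3, which carries a methylsulfonylamino group, stays at the limit, while compound 2, which carries no such group, yields a number, so the evidence points in neither direction cleanly. The step from compound 1 to compound 4 is expected to be a modest gain in potency, estimated as an at least 3.3-fold lower number from compound 1 to compound 4 (0.52 log units; beyond the scatter). Compound 4 is expected to give 3000 nM, with a range from 600 nM to 15000 nM, and a fair chance remains that compound 4 too is reported only as a limit.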

Compound 4, half-maximal effective concentration: > 10000 nM
Compound 4: no number, only a limit; the forecaster's own chance of this, stated with the estimate: 40%; middle value at least 3.3-fold (0.52 log units) from the limit.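

Compound 4 gives > 10000 nM in this assay, a limit of the assay and not a number. Compound 1 also stands at a limit, so no step can be read between compound 1 and compound 4: the limit of > 10000 nM in this assay, at which 3 of the 4 values shown sit. The compounds shown leave open whether (ethylsulfonyl)amino in place of pyridin-2-yl changes potency at all in this assay.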